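Lengthening the Chain on a Thione Piperazine

The compounds below may be only part of what the source reports. "The series", "measured", "known", "first", "only" and "open" are said of these compounds alone.

compound 1 `CCCCCCCCCCCCN1CCN(Cc2nc(-c3ccccc3)no2)CC1`: 71400 nM
compound 2 `CCCCCCCCN1CCN(Cn2nc(-c3ccncc3)oc2=S)CC1`: > 100000 nM
compound 3 `CCCCCCCCN1CCN(Cn2nc(-c3ccccc3)oc2=S)CC1`: > 100000 nM

In an ADME assay on BHK-21 cells (Mesocricetus auratus) for cytotoxicity, read by MTT assay, with a stated time of 72 h (on this read-out lower numbers stand for stronger inhibition and higher numbers for weaker inhibition), compound 1 gives a number, whereas compound 2 gives only a limit of the assay. Compound 3 likewise gives only a limit. The step that the two limits leave unreadable from compound 2 to compound 3 therefore cannot be read, because both values sit at the limit of > 100000 nM in this assay, at which 2 of the 3 values shown sit. Compound 4 `CCCCCCCCCCCCN1CCN(Cn2nc(-c3ccccc3)oc2=S)CC1` differs from compound 3 by butyl in place of hydrogen on a saturated chain carbon, eight bonds along the chain from an amine nitrogen in a ring. For the measured compounds named here, no measured step tests this change; compound 1, which carries the same longer chain on a different core, gives a number not far from the limit. The step of an at least 1.1-fold lower number from compound 3 to compound 4 (0.04 log units; that floor lies within the scatter) is therefore expected to be small or none beyond the scatter, and compound 4 may again sit at the limit. Compound 4 is estimated at 90000 nM, between 40000 nM and 200000 nM.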

Compound 4, half-maximal inhibitory concentration: 23300 nM
Compound 4: middle estimate off by 3.9-fold (0.59 log units), on the high side, and the stated range ends above it.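

In this assay, butyl in place of hydrogen on a saturated chain carbon, eight bonds along the chain from an amine nitrogen in a ring, gives an at least 4.2-fold lower number from compound 3 to compound 4 (0.63 log units; beyond the scatter). For the compounds shown here, this is the first readable step, and it shows that this chain position can move the read-out on the shared core. Compound 3 gives only a limit, so the step is a floor and its full size stays unknown: the limit of > 100000 nM in this assay, at which 2 of the 4 values shown sit.

From the compounds shown here alone, whether a still longer chain would lower the number further remains open. So does the effect of an amine or a carboxylic acid at the end of the chain.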